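Carbonyl to methylene at the dimethylamino-bearing position

The source may report more compounds than this note shows. Statements on the series, on what has been measured and on what is new or still open speak of the compounds shown alone.

In an ADME assay on TZM cells (Homo sapiens) for cytotoxicity, with a stated time of 1 days (on this read-out higher numbers stand for lower toxicity in this test and lower numbers for higher toxicity in this test), compound 1 `Cc1cc(CCC#N)cc(C)c1Oc1cc(Nc2ccc(C#N)cc2)c(N)cc1C(=O)N(C)C` gives 38200 nM, the lower of the two numbers in hand. Within the data shown here, compound 2 `CCNC(=O)c1cc(N)c(Nc2ccc(C#N)cc2)cc1Oc1c(C)cc(CCC#N)cc1C` gives 105000 nM in this assay; the only measured step, a 2.7-fold higher number from compound 1 to compound 2 (0.44 log units; beyond the scatter), replaces ethylamino with dimethylamino on the carbonyl carbon of the shared core.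

Compound 3 `Cc1cc(CCC#N)cc(C)c1Oc1cc(Nc2ccc(C#N)cc2)c(N)cc1CN(C)C` differs from compound 1 by (dimethylamino)methyl in place of dimethylcarbamoyl on an aromatic carbon. Among the measured compounds shown here, no measured step makes this exchange; the step from compound 1 to compound 2 alters the same dimethylcarbamoyl group but keeps its carbonyl, so it bears on the change only loosely, and it was modest in size. With nothing closer to go on, no step beyond the scatter is expected in this assay, in either direction.

The estimate for compound 3 is therefore 30000 nM, with a range from 10000 nM to 90000 nM, which is expected to mean a 1.3-fold lower number from compound 1 to compound 3 (0.10 log units; within the scatter).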

Compound 3, half-maximal cytotoxic concentration: 23800 nM
Beside the measured number, compound 3's estimate is 1.3-fold (0.10 log units) above it; the range from low to high includes it.
By their numbers in this assay, from the lowest: compounds 3 and 1 (each within the scatter of the next); then compound 2.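

In this assay, taking the carbonyl out of the dimethylcarbamoyl group while keeping the dimethylamino end gives a 1.6-fold lower number from compound 1 to compound 3 (0.21 log units; within the scatter) and so leaves the read-out at this aromatic carbon within the usual scatter. The same exchange made from the ethylcarbamoyl group gives a 4.4-fold lower number from compound 2 to compound 3 (0.64 log units; beyond the scatter) in a step beyond the scatter, so among these compounds the only steps beyond the scatter are those involving the ethylcarbamoyl group of compound 2. Nothing at hand accounts for either step.

Still open, going by these compounds, is whether (ethylamino)methyl would read closer to compound 2 or to compound 3, which would separate the effect of the carbonyl from that of the amide hydrogen. Also open, on these data alone, is how a carboxylic acid or a longer aminoalkyl chain on this aromatic carbon would read in this test.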